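This account rests on a few compounds, and the source may have more. Where it says the series, first, only, none or still open, it means among the compounds named here.

In a functional assay on 786-0 cells (Homo sapiens) for inhibition, read by sulforhodamine B assay, with a stated time of 48 h, tested at 10 uM (a lower number here means less inhibition, a higher number more inhibition at the concentration tested (going by the name of the read-out)), compound 1 `O=Cc1ccc(-c2cn3ccnc3c(-c3ccc4ncn(C5CCCCC5)c4c3)n2)cc1` gives 46.7%, compound 2 `Clc1ccc(-c2cn3ccnc3c(-c3ccc4ncn(C5CCCCC5)c4c3)n2)cc1` gives 12.1%, and compound 3 `COc1ccccc1-c1cn2ccnc2c(-c2ccc3ncn(C4CCCCC4)c3c2)n1` gives 12.3%. Among these three numbers compound 3 stands second highest: its nearest neighbour is compound 2, with a gap that lies within the scatter, and its furthest is compound 1, whose number sits beyond the scatter above it. The change from compound 1 to compound 3 was a number 34.4 percentage points lower from compound 1 to compound 3 (beyond the scatter), and from compound 2 to compound 3 it was a number 0.2 percentage points higher from compound 2 to compound 3 (within the scatter).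

Compound 4 `Fc1ccccc1-c1cn2ccnc2c(-c2ccc3ncn(C4CCCCC4)c3c2)n1` differs from compound 3 in one place: fluoro in place of methoxy on an aromatic carbon. Going by the values given here, no measured step swaps these two groups directly, so the bearing steps are only those on the same ring. The step from compound 2 to compound 3, exchanging a 4-chlorophenyl for a 2-methoxyphenyl, changed little, which suggests that a further change on this ring leaves the number near where compound 3 sits. For compound 4 in this assay a change of a number 0.7 percentage points higher from compound 3 to compound 4 (within the scatter) is therefore expected, that is, none beyond the scatter. Compound 4 is estimated at 13%, within a range from 3% to 26%.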

Compound 4, a percentage reported as inhibition, at one concentration (the size of the read-out at that concentration, not a potency): 2.94%
The estimate for compound 4 lay 10.1 percentage points above the measured number; the whole stated range lies above it.
By their numbers in this assay, from the lowest: compounds 4, 2 and 3 (each within the scatter of the next); then compound 1.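

In this assay, putting fluoro in place of methoxy on this ring, ortho to a large group, gives a number 9.4 percentage points lower from compound 3 to compound 4 (within the scatter), so the two groups are not told apart at this position. The comparison with a chloro-bearing ring gives a number 9.2 percentage points lower from compound 2 to compound 4 (within the scatter), which places the 2-fluorophenyl alongside the 4-chlorophenyl as well as the 2-methoxyphenyl. Only the 4-formylphenyl stands apart, with a number 43.8 percentage points lower from compound 1 to compound 4 (beyond the scatter), and it now does so against three different rings rather than two.

Nothing available explains why that one ring stands apart. Also open, from the compounds shown here alone, is whether a hydroxymethyl group or a carboxylic acid in place of the formyl would keep the number of compound 1 or join the other three.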